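Fluoro for cyano on the phenyl ring of compound 3

The source may hold more compounds than are shown below. What is called first, only, known or untested is meant among the compounds shown, and "the series" means these compounds.

Compound 3 `N#Cc1ccc(-c2cn(CC(=O)Nc3nc4ccccc4s3)nn2)cc1` gives, in a functional assay on BMDM cells (Mus musculus, strain C57BL/6) for inhibition, with a stated time of 2 days (on this read-out higher numbers stand for weaker inhibition and lower numbers for stronger inhibition), only a limit, > 30000 nM. That limit is the one named in the limit of > 30000 nM in this assay, at which 1 of the 3 values shown sits. Compound 2 `O=C(Cn1cc(-c2ccc([N+](=O)[O-])cc2)nn1)Nc1nc2ccccc2s1` carries nitro at the same place and gives 3280 nM in this assay. Going by the values given here, the one measured step on that ring, an at least 9.1-fold higher number from compound 2 to compound 3 (0.96 log units; beyond the scatter), went toward the limit. Compound 1 `COc1ccc(-c2cn(CC(=O)Nc3nccs3)nn2)cc1`, with methoxy on the ring and a smaller core, gives 510 nM in this assay.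

Compound 4 `O=C(Cn1cc(-c2ccc(F)cc2)nn1)Nc1nc2ccccc2s1` differs from compound 3 by fluoro in place of cyano on an aromatic carbon. Among the compounds with values here, no measured step covers fluoro at this place, and compound 3 itself has no number, only a limit; so the expectation rests on the spread between compound 2 and compound 1 on one side and the limit of compound 3 on the other. Compound 4 is estimated at 8000 nM in this assay, within 1500 nM to 40000 nM. That estimate would mean a step of an at least 3.7-fold lower number from compound 3 to compound 4 (0.57 log units; beyond the scatter) back below the limit, though a second limit is also expected to be plausible.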

Compound 4, half-maximal inhibitory concentration: > 30000 nM
Compound 4: no number, only a limit (the forecaster's own chance of this, stated with the estimate: 40%); at least 3.7-fold (0.57 log units) between middle value and limit.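

Compound 4 gives > 30000 nM in this assay as a limit of the assay and not a number, and the step from compound 3 cannot be read with limits at both ends. Fluoro in place of nitro gives an at least 9.1-fold higher number from compound 2 to compound 4 (0.96 log units; beyond the scatter) and so matches what cyano did at this place, which makes two replacements of nitro on the shared core that leave no measurable value. Nitro is now the only group at this place on that core with a number, and the values gather at the limit: the limit of > 30000 nM in this assay, at which 2 of the 4 values shown sit.

As far as these compounds go, whether an amine or a carboxylic acid at this place on the phenyl ring would bring a number back stays open. From the compounds shown here alone, compound 1 differs from the others in both ring group and core, so the effect of methoxy on the shared core also stays open.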